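This account rests on a few compounds, and the source may have more. Where it says the series, first, only, none or still open, it means among the compounds named here.

Measured so far in an ADME assay on BaF3 cells (Mus musculus) for inhibition, read by CellTiter-Glo, with a stated time of 72 h; on this read-out lower numbers stand for stronger inhibition of growth and higher numbers for weaker inhibition of growth:
compound 1 `CCN1CCN(C(=O)c2ccc(Nc3ncc4c(n3)N(C)C(=O)N(c3cc(NC(=O)c5ccc(CN6CCC(N(C)C)C6)c(C(F)(F)F)c5)ccc3C)C4)cn2)CC1` gives 704 nM
compound 2 `Cc1ccc(Nc2ncc3c(n2)N(C)C(=O)N(c2cc(NC(=O)c4ccc(-n5cccc5)c(C(F)(F)F)c4)ccc2C)C3)cn1` gives 317 nM
compound 3 `Cc1ccc(NC(=O)c2ccc(CN3CCC(N(C)C)C3)c(C(F)(F)F)c2)cc1N1Cc2cnc(Nc3cnn(C)c3)nc2N(C)C1=O` gives 414 nM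

Compound 2 has the lowest of these three numbers in this assay, within the scatter of compound 3 and beyond it only against compound 1.

Compound 4 `Cc1ccc(Nc2ncc3c(n2)N(C)C(=O)N(c2cc(NC(=O)c4ccc(N5CCN(C)CC5)c(C(F)(F)F)c4)ccc2C)C3)cn1` is not yet measured. It differs from compound 2 in one place: 4-methylpiperazin-1-yl in place of 1H-pyrrol-1-yl on an aromatic carbon. Compounds 1 and 3 carry a different group at this place, and their numbers in this assay sit close to that of compound 2, so a group change here is expected to matter little. The step is expected to be small, at most a slight weakening, a 1.4-fold higher number from compound 2 to compound 4 (0.15 log units; within the scatter), within the usual scatter. Compound 4 is therefore expected to give about 450 nM in this assay, most likely between 200 nM and 1000 nM.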

Compound 4, concentration for 50% growth inhibition: 685 nM
Compound 4: middle estimate off by 1.5-fold (0.18 log units), on the low side; low and high end bracket the measured number.
By their numbers in this assay, from the lowest: compounds 2, 3, 4 and 1 (each within the scatter of the next, the first and the last beyond it).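

Going by these compounds alone, the pair measured in this assay is the first that differs in one place only, so the group on this aromatic carbon can now be judged on its own. Putting 4-methylpiperazin-1-yl in place of 1H-pyrrol-1-yl gives a 2.2-fold higher number from compound 2 to compound 4 (0.33 log units; beyond the scatter) and this modest step shows that growth inhibition here does respond to the group at this position. Nothing at hand explains the step.

With a single swap shown, it stays open which part of the new ring goes with the step. A piperidin-1-yl or morpholin-4-yl ring, or an open-chain dimethylamino group, at this place would help to separate these parts.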